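The compounds below may be only part of what the source reports. "The series", "measured", "known", "first", "only" and "open" are said of these compounds alone.

Measured so far:
compound 1, `ClCc1ccc(Cn2cnc3c(Cl)ncnc32)cc1` — 3460 nM
compound 2, `ClCc1cccc(Cn2cnc3ncnc(Cl)c32)c1` — 14100 nM

In a functional assay on LOX IMVI cells (Homo sapiens) for cytotoxicity, read by sulforhodamine B assay, with a stated time of 48 h (on this read-out higher numbers stand for weaker inhibition of growth and lower numbers for stronger inhibition of growth), compound 1 gives 3460 nM, the lower of the two numbers; compound 2 gives 14100 nM, and the gap between the two lies beyond the scatter of this assay. Compound 3, `ClCc1ccc(Cn2cnc3c(Cl)nc(Cl)nc32)cc1`, has not yet been measured. It differs from compound 1 by chloro in place of hydrogen on an aromatic carbon, placed on an aromatic carbon of a six-membered aromatic ring with two nitrogen atoms, part of a fused system of two rings, between two ring nitrogen atoms and meta to a chloro group. Among the compounds with values here, no measured pair shows what such a change does on the shared core, so the direction of the step is open. The account expects compound 3 to show no change beyond the scatter, with the step from compound 1 estimated as a 1.2-fold lower number from compound 1 to compound 3 (0.06 log units; within the scatter). Compound 3 is expected to give about 3000 nM, within a range from 800 nM to 12000 nM.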

Compound 3, concentration for total growth inhibition: 4170 nM
Compound 3: middle estimate off by 1.4-fold (0.14 log units), on the low side; the range from low to high includes it.
By their numbers in this assay, from the lowest: compounds 1 and 3 (each within the scatter of the next); then compound 2.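

Within the data shown here, compound 1 and compound 3 are the first pair on the shared core to differ in one place, and they give this position its first reading. In this assay, chloro in place of hydrogen on an aromatic carbon, between two ring nitrogen atoms and meta to a chloro group, gives a 1.2-fold higher number from compound 1 to compound 3 (0.08 log units; within the scatter), so this position carries hydrogen or chloro with no difference beyond the scatter of the assay. No measurement given here accounts for this result.

At this position the compounds shown hold only hydrogen and chloro, so what an amine or a methoxy group would do there remains open. Whether the same change would also leave the number within the scatter on the core of compound 2 is open as well.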